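A few compounds are considered here, and "the series" means these few. Any claim that something is new, unique, unknown or untested is made for them only; others in the source may bear on it.

Measured so far:
- Compound 1 `Fc1cc(-c2csc(NCC3CCOCC3)n2)c(Cl)cn1`: > 10000 nM, a limit of the assay
- Compound 2 `COCCN[C@H]1CC[C@H](Nc2cc(-c3csc(SCC4CCOCC4)n3)c(Cl)cn2)CC1`: 340 nM

For the measured compounds named here, in a functional assay on MV4-11 cells (Homo sapiens) for antiproliferative activity, read by CellTiter-Glo, with a stated time of 72 h (a higher number here means a weaker inhibitor of growth, a lower number a stronger inhibitor of growth), compound 2 gives 340 nM, the only actual number so far. Compound 1 gives only a limit.

The next compound is compound 3 `COCCN[C@H]1CC[C@H](Nc2cc(-c3csc(NCC4CCCCC4)n3)c(Cl)cn2)CC1`, which carries (cyclohexylmethyl)amino in place of ((oxan-4-yl)methyl)sulfanyl on an aromatic carbon. Going by the values given here, no measured pair covers this swap, so the estimate rests on compound 2 at 340 nM alone and its range is kept wide. A modest shift toward stronger growth inhibition is expected in this assay, with the estimated step of a 1.7-fold lower number from compound 2 to compound 3 (0.23 log units; within the scatter), and a result within the usual scatter would fit this expectation as well. Compound 3 is expected at 200 nM, with an estimated range of 40 nM to 1000 nM.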

Compound 3, concentration for 50% growth inhibition: 820 nM
For compound 3 the middle estimate is 4.1-fold (0.61 log units) below the measured one, within the range that was stated.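

For the compounds shown here, this is the first comparison that differs in one place: in this assay, (cyclohexylmethyl)amino in place of ((oxan-4-yl)methyl)sulfanyl on an aromatic carbon of the five-membered aromatic ring gives a 2.4-fold higher number from compound 2 to compound 3 (0.38 log units; beyond the scatter). Compound 3 still gives a measured value of 820 nM, so growth inhibition remains measurable with either group at this position. The swap exchanges the linking sulfur for nitrogen and the ring oxygen for carbon at once, so the step cannot be divided between the two, and no measurement at hand accounts for it.

From the compounds shown here alone, the hybrids ((oxan-4-yl)methyl)amino and (cyclohexylmethyl)sulfanyl would separate the two exchanges, and their effect remains open. Also open, going by these compounds, is how a plain amino group or a longer alkyl chain on this carbon would read.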